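Swapping the halogenated arm on a shared nucleoside core

The source may hold more compounds than are shown below. What is called first, only, known or untested is meant among the compounds shown, and "the series" means these compounds.

Compound 1 `OC[C@H]1O[C@@H](n2cnc3c(NCc4ccc(Br)cc4)ncnc32)[C@H](O)[C@@H]1O` carries a 4-bromophenyl group on a saturated chain carbon bound to a nitrogen on an aromatic ring. Among the measured compounds shown here, in a functional assay on K562 cells (Homo sapiens) for antiproliferative activity, with a stated time of 72 h (a higher number here means a weaker inhibitor, a lower number a stronger inhibitor), compound 1 gives 68200 nM, one of only two plain numbers in this small set, the other belonging to compound 2. Compound 2 `COc1ccccc1CNc1ncnc2c1ncn2[C@@H]1O[C@H](CO)[C@@H](O)[C@H]1O` gives 89000 nM in this assay, and a 1.3-fold higher number from compound 1 to compound 2 (0.12 log units; within the scatter). Compound 3 `COc1cc(CNc2ncnc3c2ncn3[C@@H]2O[C@H](CO)[C@@H](O)[C@H]2O)cc(OC)c1` reaches only a limit of the assay, > 166000 nM (the limit of > 166000 nM in this assay, at which 1 of the 3 values shown sits). Against it, an at least 2.4-fold higher number from compound 1 to compound 3 (0.38 log units; beyond the scatter), while an at least 1.8-fold higher number from compound 2 to compound 3 (0.27 log units; that floor lies within the scatter).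

Compound 4 `OC[C@H]1O[C@@H](n2cnc3c(NCc4ccc(F)cc4Cl)ncnc32)[C@H](O)[C@@H]1O` differs from compound 1 by a single change: 2-chloro-4-fluorophenyl in place of 4-bromophenyl on a saturated chain carbon bound to a nitrogen on an aromatic ring. For the measured compounds named here, no measured step exchanges one halogen pattern for another; the two steps that start from compound 1 replace its halogenated ring with methoxy-bearing rings, and only the step to compound 3 moves beyond the scatter. A change that keeps a halogenated ring is therefore expected to leave the number roughly where it is. Compound 4 is expected to sit close to its parent, giving a 1.1-fold higher number from compound 1 to compound 4 (0.04 log units; within the scatter). Compound 4 is estimated at 75000 nM, with a range from 35000 nM to 160000 nM.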

Compound 4, half-maximal inhibitory concentration: 15600 nM
The estimate for compound 4 lay 4.8-fold (0.68 log units) above the measured number; measured number outside the range, below it.
By their numbers in this assay, from the lowest: compound 4; then compounds 1 and 2 (each within the scatter of the next). At a limit, above all of these: compound 3.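

Among the compounds shown here, earlier changes on a saturated chain carbon bound to a nitrogen on an aromatic ring had left the number within the scatter or raised it, and in this assay the 2-chloro-4-fluorophenyl group is the first to lower it, with a 4.4-fold lower number from compound 1 to compound 4 (0.64 log units; beyond the scatter) and with a 5.7-fold lower number from compound 2 to compound 4 (0.76 log units; beyond the scatter) as well. Exchanging one halogenated ring for another is therefore not neutral at this position, and compound 4 is the strongest inhibitor of the four. The widest gap is an at least 10-fold lower number from compound 3 to compound 4 (1.02 log units; beyond the scatter) and it rests on a limit, not a number: the limit of > 166000 nM in this assay, at which 1 of the 4 values shown sits.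

The compounds shown leave open which part of the change matters, the chlorine, the fluorine or the loss of the bromine, and a 4-chlorophenyl or 4-fluorophenyl group would separate these. Also open, on these data alone, is how a cyclohexyl group in place of the aromatic ring would read in this assay here.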